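Dialkylamino chain variants in an antiproliferative series

This account rests on a few compounds, and the source may have more. Where it says the series, first, only, none or still open, it means among the compounds named here.

Measured so far:
compound 1, `CN(C)CCn1c(N)c(-c2nc3ccccc3[nH]2)c2nc(C#N)c(C#N)nc21`, 2220 nM
compound 2, `CCN(CC)CCn1c(N)c(-c2nc3ccccc3[nH]2)c2nc(C#N)c(C#N)nc21`, 1880 nM
compound 3, `CN(C)CCCCn1c(N)c(-c2nc3ccccc3o2)c2nc(C#N)c(C#N)nc21`, 640 nM

All three were run in a functional assay on HL-60 cells (Homo sapiens) for antiproliferative activity, read by MTT assay, with a stated time of 48 h; on this read-out lower numbers stand for stronger inhibition and higher numbers for weaker inhibition. Compound 1 and compound 2 share a core and differ only in the amine: diethylamino in place of dimethylamino on a saturated chain carbon, two bonds along the chain from an aromatic nitrogen. The step is a 1.2-fold lower number from compound 1 to compound 2 (0.07 log units; within the scatter), so the two values are not separated. Compound 3 carries a different core; the difference between the two cores is not broken down here. Its number is the lowest of the three, lower than that of compound 2 and of compound 1 by more than the usual scatter.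

Compound 4, `CCN(CC)CCCCn1c(N)c(-c2nc3ccccc3o2)c2nc(C#N)c(C#N)nc21`, is not yet measured. It relates to compound 3 as compound 2 relates to compound 1: diethylamino in place of dimethylamino on a saturated chain carbon, four bonds along the chain from an aromatic nitrogen. The place differs, four bonds along the chain from an aromatic nitrogen rather than two, so this is the same kind of change, not the same one. In this assay the step from compound 3 to compound 4 is expected to be about a 1.2-fold lower number from compound 3 to compound 4 (0.07 log units; within the scatter), resting on the near-flat a 1.2-fold lower number from compound 1 to compound 2 (0.07 log units; within the scatter); compound 4 is therefore estimated at 550 nM, between 250 nM and 1200 nM.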

Compound 4, half-maximal inhibitory concentration: 450 nM
Compound 4: the middle estimate sits 1.2-fold (0.09 log units) above what was measured, and the stated range covers the measured number.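

In this assay, diethylamino in place of dimethylamino gives a 1.4-fold lower number from compound 3 to compound 4 (0.15 log units; within the scatter), so on the core of compound 3 this change again leaves the number unresolved from that of its dimethylamino partner. The two steps cannot be told apart, and the change carries across these two cores without a separable difference: the same change on two cores in this assay, a 1.2-fold lower number (0.07 log units; within the scatter) from compound 1 to compound 2 and a 1.4-fold lower number (0.15 log units; within the scatter) from compound 3 to compound 4, 1.2-fold (0.08 log units) apart, within the scatter of two such steps

This holds for two pairs only, which differ in core and in the place of the amine, two bonds along the chain from an aromatic nitrogen in one pair and four bonds in the other, so it does not show that the step would stay flat on other cores or with other amines.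

The compounds shown leave open how much of the lower numbers of the four-bond pair belongs to the chain and how much to the core, since no pair here changes only one of the two. Also open, going by these compounds, is whether a cyclic amine such as piperidine or morpholine, or a longer chain, would move the number beyond the scatter.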